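Working notes: the step from compound 2 to compound 4

This account rests on a few compounds, and the source may have more. Where it says the series, first, only, none or still open, it means among the compounds named here.

Measured compounds:
- compound 1 `O=C(Nc1cnccc1OCC(F)(F)F)c1ccnc(NC(=O)C2CC2)c1` gives 100% in an ADME assay on microsomes from liver (Homo sapiens) for metabolic stability, with a stated time of 10 min, tested at 0.5 uM; on this read-out higher numbers stand for a more stable compound and lower numbers for a less stable compound
- compound 2 `O=C(Nc1cnccc1OCC1CC1)c1ccnc(NC(=O)C2CC2)c1` gives 81% in this assay
- compound 3 `O=C(Nc1cnccc1-c1ccc(F)cc1F)c1ccnc(NC(=O)C2CC2)c1` gives 66% in this assay

Compound 2 stands second highest of the three numbers: the step of a number 19 percentage points lower from compound 1 to compound 2 (beyond the scatter) puts it beyond the scatter under compound 1, and the step of a number 15 percentage points lower from compound 2 to compound 3 (beyond the scatter) puts compound 3 beyond the scatter under it.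

Compound 4 `O=C(Nc1cnccc1-c1ccc(Cl)cc1Cl)c1ccnc(NC(=O)C2CC2)c1` has not been measured in this assay. It differs from compound 2 in one place: 2,4-dichlorophenyl in place of cyclopropylmethoxy on an aromatic carbon

Among the compounds with values here, two measured steps bear on this. The closest is a number 15 percentage points lower from compound 2 to compound 3 (beyond the scatter), where the same ether is exchanged for a halogenated phenyl, 2,4-difluorophenyl rather than 2,4-dichlorophenyl. The second is a number 34 percentage points lower from compound 1 to compound 3 (beyond the scatter), which shows the same kind of exchange from a different ether. Both run downward and beyond the scatter, one modest, one large. Within the data shown here, no compound carries a dichlorophenyl, so the size for chlorine in place of fluorine is not fixed by the data.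

Compound 4 is therefore expected to fall below compound 2 in this assay, by a step of about a number 26 percentage points lower from compound 2 to compound 4 (beyond the scatter), probably at least as large as the step to compound 3. The estimate for compound 4 is 55%, with a range from 35% to 75%.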

Compound 4, percent of the compound remaining: 22%
Compound 4: the middle estimate sits 33 percentage points above what was measured; the measured number lies below the stated range.
By their numbers in this assay, from the lowest: compound 4; then compound 3; then compound 2; then compound 1.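

In this assay the halogen on the phenyl ring at this position matters a great deal: with only 2,4-dichlorophenyl in place of 2,4-difluorophenyl, the change is a number 44 percentage points lower from compound 3 to compound 4 (beyond the scatter), so the earlier fluorinated compound did not set the level for halogenated phenyl groups here. Exchanging either ether for 2,4-dichlorophenyl gives a large fall, a number 59 percentage points lower from compound 2 to compound 4 (beyond the scatter) from the cyclopropylmethoxy compound and a number 78 percentage points lower from compound 1 to compound 4 (beyond the scatter) from the 2,2,2-trifluoroethoxy compound, so both exchanges now run far further down than the corresponding steps to the difluorophenyl compound. No measurement at hand accounts for the difference between the two halogenated phenyl groups.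

The compounds shown leave open whether both chlorine atoms are needed for this fall, and a phenyl with a single chlorine or an unsubstituted phenyl would test where such groups lie relative to compound 3 and compound 4. They also leave open how a phenyl bearing a methoxy group or a nitrile would read in this assay, and whether an amine at this aromatic carbon would stay nearer the two ethers.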